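Benzyl ring swap on the amide-type nitrogen

A few compounds are considered here, and "the series" means these few. Any claim that something is new, unique, unknown or untested is made for them only; others in the source may bear on it.

Among the measured compounds shown here, in a functional assay on Jurkat cells (Homo sapiens) (on this read-out higher numbers stand for weaker inhibition and lower numbers for stronger inhibition), compound 2 `C[C@H](NC(=O)C(=O)NCc1cccc(F)c1)C(=O)N[C@@H](CC(=O)O)C(=O)COc1c(F)c(F)cc(F)c1F` reads 106 nM and is the higher of the two numbers so far, while compound 1 `C[C@H](NC(=O)C(=O)Nc1cccnc1N(C)C)C(=O)N[C@@H](CC(=O)O)C(=O)COc1c(F)c(F)cc(F)c1F` reads 27 nM on the same read-out. Compound 3 `Cc1cccc(CNC(=O)C(=O)N[C@@H](C)C(=O)N[C@@H](CC(=O)O)C(=O)COc2c(F)c(F)cc(F)c2F)c1C` differs from compound 2 in one place: 2,3-dimethylphenyl in place of 3-fluorophenyl on a saturated chain carbon bound to an amide-type nitrogen is the whole change, 2,3-dimethylphenyl in place of 3-fluorophenyl on a saturated chain carbon bound to an amide-type nitrogen. For the measured compounds named here, one measured step bears on it, a 3.9-fold higher number from compound 1 to compound 2 (0.59 log units; beyond the scatter) which is modest but beyond the scatter. Going by the values given here, that step exchanged a whole group, and no measured pair varies the benzyl ring alone. A smaller step is therefore expected in this assay with no firm direction. The expected step is a 1.2-fold lower number from compound 2 to compound 3 (0.07 log units; within the scatter) and stays within the scatter. For compound 3 the estimated value is 90 nM with an expected range from 35 nM to 230 nM around it.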

Compound 3, half-maximal inhibitory concentration: 102 nM
Estimate against measurement, compound 3: 1.1-fold (0.05 log units) below; measured number inside the range.
By their numbers in this assay, from the lowest: compound 1; then compounds 3 and 2 (each within the scatter of the next).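

In this assay, 2,3-dimethylphenyl on a saturated chain carbon bound to an amide-type nitrogen reads as 3-fluorophenyl does, with a 1.0-fold lower number from compound 2 to compound 3 (0.02 log units; within the scatter), so these two substituted rings cannot be told apart at this position. Both benzyl compounds stand apart from compound 1, with a 3.8-fold higher number from compound 1 to compound 3 (0.58 log units; beyond the scatter) alongside a 3.9-fold higher number from compound 1 to compound 2 (0.59 log units; beyond the scatter), each modest but beyond the scatter. Nothing available explains either step.

Still open, on these data alone, is whether the lower number of compound 1 goes with its pyridine ring, its dimethylamino group or the lack of a saturated chain carbon on the amide-type nitrogen. Also open, as far as these compounds go, is how an unsubstituted benzyl group, or a benzyl ring bearing a methoxy group or a carboxylic acid, would read here.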